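Trifluoromethoxy in Place of Fluoro in HeLa Cytotoxicity

A few compounds are considered here, and "the series" means these few. Any claim that something is new, unique, unknown or untested is made for them only; others in the source may bear on it.

Compound 1, `Cc1ccc2c(=O)[nH]c(-c3ccccc3OC(F)(F)F)nc2c1`, gives 18300 nM in a functional assay on HeLa cells (Homo sapiens) for cytotoxicity, read by MTT assay, with a stated time of 2 days; a higher number here means a weaker inhibitor, a lower number a stronger inhibitor.
Compound 2, `Cc1ccc2c(=O)[nH]c(-c3ccccc3F)nc2c1`, gives 830 nM in this assay.
Compound 3, `Cc1ccc2nc(-c3cccc(F)c3)[nH]c(=O)c2c1`, reaches only the limit > 50000 nM in this assay; that is a limit of the assay, not a number.

The change trifluoromethoxy in place of fluoro on an aromatic carbon produced a 22-fold higher number from compound 2 to compound 1 (1.34 log units; beyond the scatter). Compound 2 and compound 3 have the same atoms joined differently; the difference between the two cores is not broken down here. Compound 4, `Cc1ccc2nc(-c3cccc(OC(F)(F)F)c3)[nH]c(=O)c2c1`, arises from compound 3 by trifluoromethoxy in place of fluoro on an aromatic carbon, the same kind of change, though here the place is meta to a large group rather than ortho to it. Because compound 3 already sits at the limit of > 50000 nM in this assay, at which 1 of the 3 values shown sits, and the earlier step of this kind went to a higher number, compound 4 is expected to stay at or past that limit, an estimated step that the limit leaves unreadable from compound 3 to compound 4. The value of compound 4 is estimated at 100000 nM, between 40000 nM and 500000 nM.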

Compound 4, half-maximal inhibitory concentration: > 50000 nM
Compound 4 ended at the assay's limit (the forecaster's own chance of this, stated with the estimate: 85%); the middle value is on the limit's open side.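

Compound 3 and compound 4 both stand at a limit rather than a number, so the step between them cannot be read: the limit of > 50000 nM in this assay, at which 2 of the 4 values shown sit.
The compounds shown leave open whether trifluoromethoxy in place of fluoro, meta to a large group, changes the number in this assay at all.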